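Vinyl in place of hydrogen on the piperidine methyl carbon

The source may hold more compounds than are shown below. What is called first, only, known or untested is meant among the compounds shown, and "the series" means these compounds.

Measured compounds:
- compound 1 `C=CCCN1CCC(CCCn2c(COc3ccccc3)nc3c(OCCCN4CCCCC4)cccc32)CC1`: 0.707 nM
- compound 2 `CN1CCC(CCCn2c(COc3ccccc3)nc3c(OCCCN4CCCCC4)cccc32)CC1`: 1.62 nM
- compound 3 `C(=C\c1ccccc1)\CN1CCC(CCCn2c(COc3ccccc3)nc3c(OCCCN4CCCCC4)cccc32)CC1`: 0.183 nM

In an in vitro assay on AV12 cells for binding affinity to Neuropeptide Y receptor type 1 (Homo sapiens) (a higher number here means a weaker inhibitor, a lower number a stronger inhibitor), compound 2 gives the highest number of the three, with compound 1 nearest and compound 3 furthest. Compound 4 `C=CCN1CCC(CCCn2c(COc3ccccc3)nc3c(OCCCN4CCCCC4)cccc32)CC1` differs from compound 2 by vinyl in place of hydrogen on a saturated chain carbon bound to an amine nitrogen in a ring. Among the compounds with values here, the steps that bear on this are a 2.3-fold higher number from compound 1 to compound 2 (0.36 log units; beyond the scatter) and an 8.9-fold lower number from compound 2 to compound 3 (0.95 log units; beyond the scatter): each group added on this carbon in place of hydrogen lowered the number. Vinyl is smaller than either allyl or 2-phenylethenyl, so a modest lowering, beyond the scatter but short of the step to compound 1, is expected for compound 4, namely a 2.0-fold lower number from compound 2 to compound 4 (0.31 log units; beyond the scatter). Compound 4 is thus estimated at 0.8 nM, within 0.35 nM to 1.8 nM.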

Compound 4, inhibition constant: 1.63 nM
The estimate for compound 4 lay 2.0-fold (0.31 log units) below the measured number, and the stated range covers the measured number.
By their numbers in this assay, from the lowest: compound 3; then compound 1; then compounds 2 and 4 (each within the scatter of the next).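

In this assay vinyl on the saturated chain carbon bound to an amine nitrogen in a ring does not separate from hydrogen (a 1.0-fold higher number from compound 2 to compound 4 (0.00 log units; within the scatter)), so placing a group on this carbon does not by itself lower the number. Among the groups shown, the lowering appears only with allyl and 2-phenylethenyl (a 2.3-fold higher number from compound 1 to compound 4 (0.36 log units; beyond the scatter); an 8.9-fold higher number from compound 3 to compound 4 (0.95 log units; beyond the scatter)). No available data explain this difference. The compounds shown leave open how a saturated propyl chain or a benzyl group on this carbon would compare.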